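The compounds below may be only part of what the source reports. "The series", "measured", "known", "first", "only" and "open" are said of these compounds alone.

Compound 1 has the structure `CNC(=O)/C=C(\C)c1ccc(NC(=O)Nc2ccc(Cl)c(C(F)(F)F)c2)cc1`; in a functional assay on HT-29 cells (Homo sapiens) for inhibition, read by MTT assay, with a stated time of 120 h (a lower number here means a stronger inhibitor, a higher number a weaker inhibitor), compound 1 gives > 50000 nM, a limit of the assay rather than a number.
Compound 2 has the structure `CNC(=O)/C=C/c1ccc(NC(=O)Nc2ccc(Cl)c(C(F)(F)F)c2)cc1`; in this assay compound 2 gives 11700 nM.
Compound 3 has the structure `CNC(=O)c1cccc(-c2ccc(NC(=O)Nc3ccc(Cl)c(C(F)(F)F)c3)cc2)c1`; in this assay compound 3 gives 29300 nM.

Of the two numbers recorded, compound 2 holds the lower one; the nearest neighbour is compound 3, and that step, a 2.5-fold higher number from compound 2 to compound 3 (0.40 log units; beyond the scatter), lies beyond the scatter. For compound 1 the assay reached only its limit (the limit of > 50000 nM in this assay, at which 1 of the 3 values shown sits), so the steps of an at least 4.2-fold lower number from compound 1 to compound 2 (0.63 log units; beyond the scatter) and an at least 1.7-fold lower number from compound 1 to compound 3 (0.23 log units; that floor lies within the scatter) set floors rather than sizes.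

Compound 4, with the structure `CC(NC(=O)/C=C/c1ccc(NC(=O)Nc2ccc(Cl)c(C(F)(F)F)c2)cc1)c1ccccc1`, is reached from compound 2 by one change: 1-phenylethyl in place of methyl on an amide-type nitrogen. For the measured compounds named here, none of the measured steps touches that amide nitrogen; all three of them rearrange the group that connects the shared core to the methylcarbamoyl unit, so they bear on the new change only indirectly. In the absence of a measured step at the amide nitrogen, the expectation for compound 4 is a change that stays within the scatter, or at most a small one, with a wide spread. Compound 4 is therefore estimated at 8000 nM, between 2500 nM and 30000 nM, which is expected to correspond to a step of a 1.5-fold lower number from compound 2 to compound 4 (0.17 log units; within the scatter).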

Compound 4, half-maximal inhibitory concentration: 1060 nM
Compound 4: the middle estimate sits 7.5-fold (0.88 log units) above what was measured; the measured number lies below the stated range.
By their numbers in this assay, from the lowest: compound 4; then compound 2; then compound 3. At a limit, above all of these: compound 1.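

For the compounds shown here, the amide-type nitrogen, which none of the earlier steps touched, proves to be a place where this assay responds strongly: 1-phenylethyl in place of methyl gives an 11-fold lower number from compound 2 to compound 4 (1.04 log units; beyond the scatter). The earlier steps shown here changed only the group that connects the shared core to the methylcarbamoyl unit, whereas this one shows that the far end of that unit also counts, with a single substituent of 8 heavy atoms and one six-membered aromatic ring replacing a methyl of 1 heavy atom and moving the number well beyond the scatter. Nothing available here explains why this change has so large an effect.

On these data alone, it remains open whether the aromatic ring or the additional carbon of 1-phenylethyl carries the step, a question that benzyl, cyclohexyl or isopropyl on the same nitrogen would help to separate. Also open, as far as these compounds go, are whether the same exchange would lower the number when made on the methylcarbamoyl group of compound 3, and how an amine or a carboxylic acid on the added ring would alter the result.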